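The compounds below may be only part of what the source reports. "The series", "measured", "known", "first", "only" and "open" are said of these compounds alone.

The compounds measured so far, with their numbers:

compound 1, `COc1ccc2nc(NC(=O)c3cc(-c4ccc(F)cc4)n4nc(-c5ccccc5)cc4n3)sc2c1`: 24500 nM
compound 2, `COc1ccc2nc(NC(=O)c3cc(-c4ccc(OC)c(OC)c4)n4nc(-c5ccccc5)cc4n3)sc2c1`: 18700 nM
compound 3, `COc1ccc2nc(NC(=O)c3cc(-c4cc(OC)c(OC)c(OC)c4)n4nc(-c5ccccc5)cc4n3)sc2c1`: 2950 nM

All three share the same core and differ only in the aryl group attached to it. In a functional assay on MCF7 cells (Homo sapiens) for cytotoxicity, read by MTT assay, with a stated time of 48 h (a lower number here means a stronger inhibitor, a higher number a weaker inhibitor), compound 2 stands second highest of the three numbers. The step of a 1.3-fold lower number from compound 1 to compound 2 (0.12 log units; within the scatter) lies within the scatter, so compound 1 and compound 2 cannot be told apart on these numbers, whereas the step of a 6.3-fold lower number from compound 2 to compound 3 (0.80 log units; beyond the scatter) does exceed it, as does an 8.3-fold lower number from compound 1 to compound 3 (0.92 log units; beyond the scatter).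

Compound 4, `COc1ccc(-c2cc(C(=O)Nc3nc4cc(C)c(C)cc4s3)nc3cc(-c4ccccc4)nn23)cc1OC`, differs from compound 2 in a different part of the molecule: 5,6-dimethyl-1,3-benzothiazol-2-yl in place of 6-methoxy-1,3-benzothiazol-2-yl on an amide-type nitrogen. None of the three measured steps touches this side of the core; each of them alters only the aryl group on the other side. For the measured compounds named here, there is therefore no measured step that bears directly on this change, and the data give no basis for expecting a move beyond the scatter in either direction in this assay. For compound 4 the estimate is 18000 nM, with a range from 6000 nM to 55000 nM. The step from compound 2 that this estimate means, a 1.0-fold lower number from compound 2 to compound 4 (0.02 log units; within the scatter), is expected to stay within the scatter.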

Compound 4, half-maximal inhibitory concentration: 2510 nM
Compound 4: the middle estimate sits 7.2-fold (0.86 log units) above what was measured, outside the stated range (below it).
By their numbers in this assay, from the lowest: compounds 4 and 3 (each within the scatter of the next); then compounds 2 and 1 (each within the scatter of the next).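

Replacing 6-methoxy-1,3-benzothiazol-2-yl with 5,6-dimethyl-1,3-benzothiazol-2-yl on the amide-type nitrogen gives a 7.5-fold lower number from compound 2 to compound 4 (0.87 log units; beyond the scatter) in this assay. For the compounds shown here, the earlier compounds varied only the aryl group on the other side of the shared core, so this is the first sign that the group on the amide-type nitrogen can also move the number beyond the scatter. Nothing measured here accounts for this step, so it stands as an observation without an explanation.

This single swap removes a methoxy group and adds two methyl groups at once, so the compounds shown cannot say whether the change depends on losing the one, gaining the other or both, and a plain 1,3-benzothiazol-2-yl or one carrying a chlorine atom or an amine would help to separate these possibilities. Going by these compounds, it also remains open whether 5,6-dimethyl-1,3-benzothiazol-2-yl would lower the number in the same way when paired with the 3,4,5-trimethoxyphenyl group of compound 3.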